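Thioether side chains on a shared core: halogen, methyl, chain length

This account rests on a few compounds, and the source may have more. Where it says the series, first, only, none or still open, it means among the compounds named here.

Measured compounds in an assay on microsomes for inhibition of Amine oxidase [flavin-containing] B (Homo sapiens), read by fluorescence and spectrophotometry, with a stated time of 20 min; on this read-out lower numbers stand for stronger inhibition and higher numbers for weaker inhibition:
compound 1 `Cn1c(=O)c2c(nc(SCCc3ccc(Br)cc3)n2C)n(C)c1=O` gives 19 nM
compound 2 `Cc1ccc(CCSc2nc3c(c(=O)n(C)c(=O)n3C)n2C)cc1` gives 72 nM
compound 3 `Cn1c(=O)c2c(nc(SCCCc3ccc(Cl)cc3)n2C)n(C)c1=O` gives 61 nM

Among the three numbers compound 2 stands highest. Its nearest neighbour is compound 3, a gap that lies within the scatter, so no order between compound 2 and compound 3 can be claimed; the step of a 3.8-fold higher number from compound 1 to compound 2 (0.58 log units; beyond the scatter) is beyond the scatter, so compound 1 stands apart from compound 2.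

Compound 4 `Cn1c(=O)c2c(nc(SCc3cccc(Cl)c3)n2C)n(C)c1=O` is not yet measured. From compound 2 it differs in one place: 3-chlorophenyl in place of 4-methylbenzyl on a saturated chain carbon bound to a sulfur. The change thus removes a methyl-bearing ring in favour of a chlorine-bearing ring and shortens the chain by one carbon.

Two measured steps bear on it only in part. a 3.8-fold higher number from compound 1 to compound 2 (0.58 log units; beyond the scatter) shows that swapping a halogen for methyl on the ring costs a modest amount, so the reverse direction may be favourable. a 3.2-fold higher number from compound 1 to compound 3 (0.51 log units; beyond the scatter) shows that lengthening the chain by one carbon, with chlorine for bromine, also costs a modest amount; whether shortening the chain helps is not shown by any pair here, and a 1.2-fold lower number from compound 2 to compound 3 (0.07 log units; within the scatter) is within the scatter. The chlorine is expected to pull the number down somewhat, the chain change is an open question, so a modest step downward is expected, a 1.6-fold lower number from compound 2 to compound 4 (0.20 log units; within the scatter). Compound 4 is therefore estimated at 45 nM, with a range from 15 nM to 160 nM.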

Compound 4, half-maximal inhibitory concentration: 227 nM
Estimate against measurement, compound 4: 5.0-fold (0.70 log units) below, outside the stated range (above it).
By their numbers in this assay, from the lowest: compound 1; then compounds 3 and 2 (each within the scatter of the next); then compound 4.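

In this assay, the halogen-for-methyl reading from the earlier pair does not carry over to this position: a 3.2-fold higher number from compound 2 to compound 4 (0.50 log units; beyond the scatter), so a chlorine-bearing ring on a saturated chain carbon bound to a sulfur does not by itself give a lower number. Against the bromine-bearing compound the loss is far larger, a 12-fold higher number from compound 1 to compound 4 (1.08 log units; beyond the scatter), which makes this the largest step in the set and shows that the group on this carbon can move the number well beyond the modest steps seen earlier. No measurement here accounts for the rise in the number, and no explanation of it can be drawn from the data given.

The compounds shown leave open how the step divides between the change of ring substitution and the change from a benzyl to a phenyl group, as both occur together in compound 4 and no compound separates them. Also open, as far as these compounds go, is how this position responds to groups of a different kind, such as an amine or a carboxylic acid on the chain, or a longer chain carrying the same 3-chlorophenyl ring.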